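Cytotoxicity notes on compounds 1 to 4

This account rests on a few compounds, and the source may have more. Where it says the series, first, only, none or still open, it means among the compounds named here.

Measured so far:
compound 1 `O=c1ncccn1SCCc1ccc(Nc2ncc(Cc3c(F)cccc3F)o2)cc1` — > 100000 nM
compound 2 `Fc1cccc(F)c1Cc1cnc(Nc2ccc(Oc3cccnc3)c(Br)c2)o1` — 7500 nM
compound 3 `COCc1ccc(Nc2nnc(Cc3c(Cl)cccc3Cl)o2)cc1` — 100000 nM

In an ADME assay on MT2 cells (Homo sapiens) for cytotoxicity, read by MTT assay (on this read-out lower numbers stand for higher toxicity in this test and higher numbers for lower toxicity in this test), compound 1 gives > 100000 nM, which is a limit of the assay and not a number. Compound 1 thus sits at the limit of > 100000 nM in this assay, at which 1 of the 3 values shown sits. In this assay compound 2 gives 7500 nM. In this assay compound 3 gives 100000 nM. Among the compounds with values here, no two of the measured compounds differ in only one place, so no measured step is available.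

Compound 4 `Fc1cccc(F)c1Cc1cnc(Nc2ccc(Oc3ccncc3)cc2)o1` has yet to be measured in this assay. It differs from compound 1 in this way: a group of 7 heavy atoms (5 carbon, 1 nitrogen, 1 oxygen; one six-membered aromatic ring with 1 hetero atom) in place of a group of 10 heavy atoms (6 carbon, 2 nitrogen, 1 oxygen, 1 sulfur; one six-membered aromatic ring with 2 hetero atoms), on an aromatic carbon. Among the measured compounds, the closest in structure to compound 4 is compound 2, whose value of 7500 nM is the main reference.

Compound 4 is expected to give about 20000 nM in this assay, with a range of 5000 nM to 100000 nM. The expected step is an at least 5.0-fold lower number from compound 1 to compound 4 (0.69 log units; beyond the scatter), toward higher toxicity in this assay and beyond the usual scatter, though the limit for compound 1 leaves its size uncertain.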

Compound 4, half-maximal cytotoxic concentration: 21000 nM
Beside the measured number, compound 4's estimate is 1.1-fold (0.02 log units) below it, and the stated range covers the measured number.
By their numbers in this assay, from the lowest: compound 2; then compound 4; then compound 3.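

In this assay, setting (pyridin-4-yl)oxy in place of the larger group with its six-membered aromatic ring of 2 hetero atoms, on an aromatic carbon para to a large group, gives an at least 4.7-fold lower number from compound 1 to compound 4 (0.67 log units; beyond the scatter). Within the data shown here, this is the first single-place change, and it shows that the group at this position can move the read-out toward higher toxicity in this test. The size of the step stays open on one side, since the value of compound 1 is a limit of the assay and not a number: the limit of > 100000 nM in this assay, at which 1 of the 4 values shown sits.

The whole group changes at once, so the compounds shown do not tell which part of it carries the step. On these data alone, how an amine or a carboxylic acid at this position would read in this assay also remains open.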